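Trifluoromethyl in place of the second aryl ring

The source may hold more compounds than are shown below. What is called first, only, known or untested is meant among the compounds shown, and "the series" means these compounds.

Three compounds of the series have numbers in an assay on isolated protein for inhibition of 2-Hydroxyacid oxidase 2 (Rattus norvegicus); on this read-out higher numbers stand for weaker inhibition and lower numbers for stronger inhibition. Compound 1 `Cc1n[nH]c(C(=O)O)c1Cc1cccc(-c2ccc(C#N)cc2)c1` gives 300 nM, compound 2 `Cc1n[nH]c(C(=O)O)c1Cc1ccc(Oc2ccccc2)cc1` gives 500 nM, and compound 3 `Cc1n[nH]c(C(=O)O)c1Cc1cccc(-c2ccccc2F)c1` gives 900 nM, the highest of the three; compound 2 lies within the scatter of compound 3, whereas the step of a 3.0-fold higher number from compound 1 to compound 3 (0.48 log units; beyond the scatter) lies beyond it. Compound 4 `Cc1n[nH]c(C(=O)O)c1Cc1cccc(C(F)(F)F)c1` differs from compound 3 by trifluoromethyl in place of 2-fluorophenyl on an aromatic carbon. Among the measured compounds shown here, no measured step exchanges an aryl ring for a group without a ring; the only step that alters the same group, a 3.0-fold higher number from compound 1 to compound 3 (0.48 log units; beyond the scatter), swaps one ring for another and gives limited guidance. The step of a 3.3-fold higher number from compound 3 to compound 4 (0.52 log units; beyond the scatter) is expected to run toward a higher number, with wide uncertainty. The estimate for compound 4 in this assay is 3000 nM, with a range from 800 nM to 12000 nM.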

Compound 4, half-maximal inhibitory concentration: 300 nM
The estimate for compound 4 lay 10-fold (1.00 log units) above the measured number, and the stated range ends above it.
By their numbers in this assay, from the lowest: compounds 1, 4, 2 and 3 (each within the scatter of the next, the first and the last beyond it).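

The second aryl ring is not required at this position: trifluoromethyl in place of 2-fluorophenyl gives a 3.0-fold lower number from compound 3 to compound 4 (0.48 log units; beyond the scatter), and trifluoromethyl in place of 4-cyanophenyl gives no change at the digits printed from compound 1 to compound 4 (within the scatter). A group without a ring on this aromatic carbon therefore does as well as the better of the two rings in these steps. No data at hand explain why the ring can be lost without a rise in the number.

From the compounds shown here alone, what a methyl group, a chlorine atom or an amine would give at this place stays open. The smallest group that keeps the number is therefore unknown.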